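The source may hold more compounds than are shown below. What is called first, only, known or untested is meant among the compounds shown, and "the series" means these compounds.

Going by the values given here, in a functional assay on Jurkat cells (Homo sapiens) for antiproliferative activity, read by MTT assay, with a stated time of 72 h (a higher number here means a weaker inhibitor, a lower number a stronger inhibitor), compound 3 `CCOc1ccc(-c2ncnn2-c2cc(OC)c(OC)c(OC)c2)cc1` gives 5 nM, the only true number among the measured compounds. Compound 1 `COc1cc(-n2ncnc2-c2ccc(Cl)cc2)cc(OC)c1OC` reads > 10000 nM, which is a limit of the assay and not a number. Compound 2 `COc1cc(-n2ncnc2-c2ccc(Cl)c(Cl)c2)cc(OC)c1OC` reads > 10000 nM, also a limit. Adding a chloro gives a step that the two limits leave unreadable from compound 1 to compound 2, so that step offers little guidance. Putting ethoxy in place of chloro gives an at least 2000-fold lower number from compound 1 to compound 3 (3.30 log units; beyond the scatter), and this is the step that bears most directly on what follows.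

Compound 4 `COc1cc(-n2ncnc2-c2ccc(F)cc2)cc(OC)c1OC` carries fluoro in place of ethoxy on an aromatic carbon, para to a large group (fluoro in place of ethoxy on an aromatic carbon). Like compound 1, it has no ethoxy, so the change is expected to undo much of the large step seen between compound 1 and compound 3, with a much higher number in this assay. The estimated step is a 2400-fold higher number from compound 3 to compound 4 (3.38 log units; beyond the scatter). For compound 4 the expected value is 12000 nM, with an estimated range of 2500 nM to 50000 nM, and the assay may well report only a limit.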

Compound 4, half-maximal inhibitory concentration: > 10000 nM
Compound 4 gave a limit, no number; the forecaster's own chance of this, stated with the estimate: 75%; the middle value lies beyond the limit too.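

In this assay, fluoro in place of ethoxy gives an at least 2000-fold higher number from compound 3 to compound 4 (3.30 log units; beyond the scatter), a figure set by a limit of the assay on one side. Until now only chloro had stood against ethoxy at this position, so the loss could have been peculiar to chloro; compound 4 shows that fluoro, a single atom in place of the 3 heavy atoms of ethoxy, does not keep the low number of compound 3 either. The steps to compound 4 from compound 1 and from compound 2 cannot be read, because all three compounds sit at the same limit: the limit of > 10000 nM in this assay, at which 3 of the 4 values shown sit.

Still open, going by these compounds, is whether ethoxy is special or whether other groups at this position would also give a low number. Methoxy, a longer chain such as propoxy, or an amine could each answer that.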